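The compounds below may be only part of what the source reports. "The series", "measured", "known", "first", "only" and "open" are said of these compounds alone.

Measured so far:
Compound 1 `Cc1cc(=O)c2c(O)cc(OCc3ccccc3Br)c([C@H]3CCN(C)C[C@H]3O)c2o1`: 30%
Compound 2 `Cc1cc(=O)c2c(O)c(CN3CCN(C(=O)OC(C)(C)C)CC3)c(O)c([C@H]3CCN(C)C[C@H]3O)c2o1`: 6%

The measurements come from a functional assay on MIA PaCa-2 cells (Homo sapiens) for inhibition, read by MTT assay, with a stated time of 48 h, tested at 10 uM; a lower number here means less inhibition of growth, a higher number more inhibition of growth at the concentration tested. Of the two compounds tested, compound 2 stands lowest at 6%. Its nearest neighbour on the numbers is compound 1 at 30%, and that gap lies beyond the usual scatter. The two compounds differ in more than one place, so their gap says nothing about any single change.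

Compound 3 `CCOC(=O)N1CCN(Cc2c(O)c([C@H]3CCN(C)C[C@H]3O)c3oc(C)cc(=O)c3c2O)CC1` has not yet been measured in this assay. It departs from compound 2 in one place: ethyl in place of tert-butyl on an oxygen next to a carbonyl group. Put another way, tert-butoxycarbonyl becomes ethoxycarbonyl. Within the data shown here, no measured pair shows this change, so its size has to be judged without a direct precedent. The expectation is for no step beyond the scatter, with any small movement more likely upward, given the low starting value of compound 2 at 6%. The expected change is a number 3 percentage points higher from compound 2 to compound 3 (within the scatter). For compound 3 the estimated value is 9%, with an expected range of 0% to 24%.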

Compound 3, percent growth inhibition at one concentration: 4%
Compound 3: middle estimate off by 5 percentage points, on the high side, and the stated range covers the measured number.
By their numbers in this assay, from the lowest: compounds 3 and 2 (each within the scatter of the next); then compound 1.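

In this assay, among these compounds, putting ethyl in place of tert-butyl on an oxygen next to a carbonyl group gives a number 2 percentage points lower from compound 2 to compound 3 (within the scatter), the first direct reading of a change at this position. At this level of resolution, tert-butoxycarbonyl and ethoxycarbonyl read alike, but with compound 2 at 6% and compound 3 at 4%, both numbers sit close to zero, where a further loss of growth inhibition would have little room to show, so the flat step does not establish that this position is indifferent to every change. Nothing available explains why the exchange leaves the number within the scatter.

The compounds shown leave open whether a benzyl group or a longer chain such as n-hexyl on this oxygen would lift the number beyond the scatter. They also leave open whether removing the whole ethoxycarbonyl group to give a free amine, or replacing it with an acetyl group, would change the reading.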